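From oxan-3-yl to oxan-4-yl in the series

The source may report more compounds than this note shows. Statements on the series, on what has been measured and on what is new or still open speak of the compounds shown alone.

In a physicochemical assay for solubility (a lower number here means a less soluble compound, a higher number a more soluble compound), compound 1 `CNC(=O)c1cc(C(=O)NC2CC2)cn(Cc2ccc(OC)cc2)c1=O` gives >= 143 ug/mL, which is a limit and not a number. Compound 2 `CNC(=O)c1cc(C(=O)NC2CC2)cn(CC2CCCOC2)c1=O` gives >= 131 ug/mL, also only a limit. Going by the values given here, the one measured step, a step that the two limits leave unreadable from compound 1 to compound 2, bears on the change but has no readable size. Compound 3 `CNC(=O)c1cc(C(=O)NC2CC2)cn(CC2CCOCC2)c1=O` differs by oxan-4-yl in place of oxan-3-yl on a saturated chain carbon bound to an aromatic nitrogen, with oxan-4-yl in place of oxan-3-yl on a saturated chain carbon bound to an aromatic nitrogen. With only a step that the two limits leave unreadable from compound 1 to compound 2 to go on, the expected step that the limit leaves unreadable from compound 2 to compound 3 is none beyond the scatter, in either direction. For compound 3 the estimate in this assay is 140 ug/mL, with an expected range of 90 ug/mL to 190 ug/mL.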

Compound 3, solubility: >= 165 ug/mL
Compound 3: only a limit was reported (the forecaster's own chance of this, stated with the estimate: 70%); middle value at least 1.1-fold (0.07 log units) from the limit.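

Going by these compounds alone, compound 1, compound 2 and compound 3 all stand as limits in this assay, and no step among them can be read. On these data alone, whether 4-methoxyphenyl, oxan-3-yl and oxan-4-yl differ at all in this assay stays open.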